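A few compounds are considered here, and "the series" means these few. Any claim that something is new, unique, unknown or untested is made for them only; others in the source may bear on it.

Measured so far:
- compound 1 `O=C(CCCCC1CCSS1)Nc1ccc([N+](=O)[O-])c(C(F)(F)F)c1`: "not active" (no number reported)
- compound 2 `O=C(CCCCC(S)CCS)Nc1cccc(C(F)(F)F)c1`: 1.97%

For the measured compounds named here, in a functional assay on KB cells (Homo sapiens) for inhibition, read by MTT assay, with a stated time of 24 h, tested at 10 ug/mL (a lower number here means less inhibition of growth, a higher number more inhibition of growth at the concentration tested), compound 2 gives 1.97%, the only number so far, as the other entry came without one. Compound 3 `O=C(CCCCC(S)CCS)Nc1ccc([N+](=O)[O-])c(C(F)(F)F)c1` differs from compound 2 by nitro in place of hydrogen on an aromatic carbon, ortho to a trifluoromethyl group and para to a large group. No measured step sizes this change. Compound 1, which also carries nitro but differs elsewhere, gives "not active" (no number reported), so no large rise is expected in this assay. The expected change a number 6 percentage points higher from compound 2 to compound 3 (within the scatter) is small, upward and within the scatter. For compound 3 the estimate is 8%, with an expected range of 0% to 35%.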

Compound 3, percent growth inhibition at one concentration: 4.04%
The estimate for compound 3 lay 4 percentage points above the measured number; low and high end bracket the measured number.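

In this assay, for the compounds shown here, the step of a number 2.1 percentage points higher from compound 2 to compound 3 (within the scatter) gives the first direct reading of nitro in place of hydrogen on this aromatic carbon, ortho to a trifluoromethyl group and para to a large group. Growth inhibition at the tested concentration does not move beyond the scatter with this change, and both compounds remain weak. Nothing measured here explains this result. From the compounds shown here alone, whether an amine or a carboxylic acid on this same carbon would shift the reading stays open, as does the effect of a longer chain on the amide carbonyl.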